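Series notes: aryl change on the ring nitrogen

The compounds below may be only part of what the source reports. "The series", "measured", "known", "first", "only" and "open" are said of these compounds alone.

Of the compounds shown here, three have been measured in a functional assay on the whole organism (strain Wistar) for inhibition, with Rattus norvegicus as the target, read by paw edema, with a stated time of 3 h, at a dose of 10 mg/kg by the oral route; a lower number here means less inhibition, a higher number more inhibition at the dose given (going by the name of the read-out). Compound 1 `Fc1ccc(Nc2nnc(COc3ccc(-c4ccccc4)cc3)o2)cc1` gives 52.3%. Compound 2 `Sc1nnc(COc2ccc(-c3ccccc3)cc2)n1-c1ccc(Cl)cc1` gives 15.9%, and compound 3 `Sc1nnc(COc2ccc(-c3ccccc3)cc2)n1-c1ccc(Br)cc1` gives 31.8%. Compound 3 thus stands second of the three numbers: compound 2 is its nearest neighbour and lies below it by a number 15.9 percentage points higher from compound 2 to compound 3 (beyond the scatter), while compound 1 lies furthest away and higher.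

Compound 4 `Cc1ccccc1-n1c(S)nnc1COc1ccc(-c2ccccc2)cc1` is not yet measured. It differs from compound 3 in one place: 2-methylphenyl in place of 4-bromophenyl on an aromatic nitrogen. Among the compounds with values here, the single measured step, a number 15.9 percentage points higher from compound 2 to compound 3 (beyond the scatter), swapped one halogen for another on the same aryl group; a change of the whole aryl group to 2-methylphenyl has no counterpart among the measured compounds. That halogen step was modest yet beyond the scatter, so a step of similar size in either direction is possible, but the data point to no direction. Compound 4 is therefore expected to give 30%, in the range 10% to 50%. This expectation amounts to a step of a number 1.8 percentage points lower from compound 3 to compound 4 (within the scatter).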

Compound 4, a percentage reported as inhibition, in the whole organism at one dose (the size of the read-out at that dose, not a potency): 56.8%
Estimate against measurement, compound 4: 26.8 percentage points below, and the stated range ends below it.
By their numbers in this assay, from the lowest: compound 2; then compound 3; then compounds 1 and 4 (each within the scatter of the next).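

In this assay, exchanging the whole aryl group on the aromatic nitrogen gives a number 25 percentage points higher from compound 3 to compound 4 (beyond the scatter), and the same exchange starting from the 4-chlorophenyl compound gives a number 40.9 percentage points higher from compound 2 to compound 4 (beyond the scatter). This position therefore allows a larger change in the read-out than the halogen exchange alone showed, at a number 15.9 percentage points higher from compound 2 to compound 3 (beyond the scatter), and a 2-methylphenyl group with no halogen is compatible with the higher numbers. The exchange alters the halogen, the methyl and the substituent's place on the aryl group all at once, and no measurement at hand assigns the step to any one of these.

As far as these compounds go, it remains open whether the rise follows the methyl or its place on the aryl group, which 4-methylphenyl and 2-chlorophenyl on the same nitrogen would separate. Also open, from the compounds shown here alone, is how cyclohexyl would read at this nitrogen.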